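A few compounds are considered here, and "the series" means these few. Any claim that something is new, unique, unknown or untested is made for them only; others in the source may bear on it.

Measured so far in a functional assay on NB1 cells (Homo sapiens) for cytotoxicity, read by MTT assay, with a stated time of 3 days; a lower number here means a stronger inhibitor, a higher number a weaker inhibitor:
- Compound 1 `N#Cc1c(Cl)nc(SCc2nc3ccccc3[nH]2)nc1-c1ccccc1`: 2.87 nM
- Compound 2 `CCNc1nc(SCc2nc3ccccc3[nH]2)nc(-c2ccccc2)c1C#N`: 2.63 nM
- Compound 3 `N#Cc1c(Nc2nccs2)nc(SCc2nc3ccccc3[nH]2)nc1-c1ccccc1`: 3.2 nM

Compound 3 cannot be separated from the other two, as the steps to it are a 1.1-fold higher number from compound 1 to compound 3 (0.05 log units; within the scatter) and a 1.2-fold higher number from compound 2 to compound 3 (0.09 log units; within the scatter). The next compound is compound 4 `CN1CCN(c2nc(SCc3nc4ccccc4[nH]3)nc(-c3ccccc3)c2C#N)CC1`, which has 4-methylpiperazin-1-yl in place of (1,3-thiazol-2-yl)amino on an aromatic carbon.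

All three measured steps bear on this change, since each swaps the group on that same carbon. Going from chloro to ethylamino gave a 1.1-fold lower number from compound 1 to compound 2 (0.04 log units; within the scatter), and replacing ethyl with 1,3-thiazol-2-yl on the nitrogen gave a 1.2-fold higher number from compound 2 to compound 3 (0.09 log units; within the scatter). Chloro, ethylamino and (1,3-thiazol-2-yl)amino have thus given no step beyond the scatter, though only three compounds show this and none carries 4-methylpiperazin-1-yl. The same is therefore expected here in this assay, with no clear direction, and the expected step is a 1.1-fold lower number from compound 3 to compound 4 (0.03 log units; within the scatter). For compound 4 the estimated value is 3 nM, with an expected range of 1.2 nM to 7.5 nM.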

Compound 4, half-maximal inhibitory concentration: 2.4 nM
Beside the measured number, compound 4's estimate is 1.3-fold (0.10 log units) above it, within the range that was stated.
By their numbers in this assay, from the lowest: compounds 4, 2, 1 and 3 (each within the scatter of the next).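

In this assay the aromatic carbon ortho to a cyano group also tolerates a six-membered non-aromatic ring: 4-methylpiperazin-1-yl gives a 1.3-fold lower number from compound 3 to compound 4 (0.12 log units; within the scatter) against (1,3-thiazol-2-yl)amino, a 1.1-fold lower number from compound 2 to compound 4 (0.04 log units; within the scatter) against ethylamino and a 1.2-fold lower number from compound 1 to compound 4 (0.08 log units; within the scatter) against chloro. The earlier compounds had shown this flat response only for chloro and two amino groups carrying a hydrogen on the nitrogen, whereas the entering group has no hydrogen-bond donor and still cannot be separated from any of the three. No measurement shown here accounts for this lack of response.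

On these data alone, whether a carboxylic acid, a primary amine or a longer alkyl chain on this carbon would move the number beyond the scatter remains open. The compounds shown also leave open whether changes elsewhere on the shared core, such as on the phenyl group, would matter more.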